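Chloro in place of methyl on the shared core

The source may report more compounds than this note shows. Statements on the series, on what has been measured and on what is new or still open speak of the compounds shown alone.

In a physicochemical assay for solubility, in phosphate buffer, measured as kinetic solubility (on this read-out higher numbers stand for higher solubility and lower numbers for lower solubility), compound 1 (`Cc1cc(C(/C=C2\OC(=O)NC2=O)C(C)C)c(=O)[nH]c1-c1ccc2cccc(F)c2c1`) gives 35700 nM. Compound 2 (`CC(C)[C@H](C[C@H]1OC(=O)NC1=O)c1ccc(-c2ccc3cccc(F)c3c2)[nH]c1=O`) gives 35400 nM, within the scatter of compound 1. Compound 3 (`CC(C)C(CC1NC(=O)NC1=O)c1ccc(-c2ccc3cccc(F)c3c2)[nH]c1=O`) gives 12300 nM, lower than compound 1 and beyond the scatter. Compound 4 (`CC(C)C(/C=C1\OC(=O)NC1=O)c1cc(Cl)c(-c2ccc3cccc(F)c3c2)[nH]c1=O`) carries chloro in place of methyl on an aromatic carbon. Among the compounds with values here, no measured pair isolates this swap, so the evidence for it is indirect. The estimate starts from compound 1 at 35700 nM. In this assay, no step beyond the scatter is expected, with a slight drop as the likeliest direction. The estimated step is a 1.3-fold lower number from compound 1 to compound 4 (0.11 log units; within the scatter). For compound 4 the expected value is 28000 nM, with an estimated range of 10000 nM to 70000 nM.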

Compound 4, solubility: 21500 nM
Compound 4: middle estimate off by 1.3-fold (0.11 log units), on the high side; the measured number falls inside the stated range.
By their numbers in this assay, from the lowest: compounds 3, 4, 2 and 1 (each within the scatter of the next, the first and the last beyond it).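

In this assay chloro in place of methyl on an aromatic carbon of the shared core gives a 1.7-fold lower number from compound 1 to compound 4 (0.22 log units; within the scatter) and so this position, two atoms from the ring nitrogen, takes the swap without a step beyond the scatter. Nothing available explains how either compound reads as it does. Still open, on these data alone, is whether an amine, a carboxylic acid or a longer chain at this position would also stay within the scatter of compound 1, and whether chloro in place of methyl would give a similar step with the side chains of compound 2 and compound 3.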